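A few compounds are considered here, and "the series" means these few. Any claim that something is new, unique, unknown or untested is made for them only; others in the source may bear on it.

Measured compounds:
compound 1, `COc1cc(-c2cc(/C=C/C(=O)c3ccc(N)cc3)[nH]n2)cc(OC)c1OC`, -13%
compound 2, `COc1cc(-c2cc(/C=C/C(=O)c3ccc(Cl)c(Cl)c3)[nH]n2)cc(OC)c1OC`, -51%

In a functional assay on SR cells (Homo sapiens) for cytotoxicity, read by sulforhodamine B assay, with a stated time of 48 h, tested at 100 uM (on this read-out higher numbers stand for a weaker effect at the one concentration tested and lower numbers for a stronger effect), compound 2 gives -51%, the lowest of the two numbers, with compound 1 the nearest at -13%. Compound 3, `COc1ccc(C(=O)/C=C/c2cc(-c3cc(OC)c(OC)c(OC)c3)n[nH]2)cc1`, has not yet been tested. It differs from compound 2 in one place: 4-methoxyphenyl in place of 3,4-dichlorophenyl on a carbonyl carbon. Within the data shown here, the only measured step, a number 38 percentage points lower from compound 1 to compound 2 (beyond the scatter), concerns the same carbonyl carbon but a different pair of groups, so it bears on compound 3 only loosely; it shows that exchange of the group on that carbonyl carbon can move the read-out by a large amount. Among the measured compounds shown here, no measured step involves 4-methoxyphenyl. Compound 3 is therefore expected to give -20%, with a range from -50% to 5%, meaning an expected step of a number 31 percentage points higher from compound 2 to compound 3 (beyond the scatter) back toward the number of compound 1.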

Compound 3, a percentage reported as activity, at one concentration (the size of the read-out at that concentration, not a potency): -5%
Compound 3: the middle estimate sits 15 percentage points below what was measured; low and high end bracket the measured number.
By their numbers in this assay, from the lowest: compound 2; then compounds 1 and 3 (each within the scatter of the next).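

In this assay, 4-methoxyphenyl in place of 3,4-dichlorophenyl on the carbonyl carbon gives a number 46 percentage points higher from compound 2 to compound 3 (beyond the scatter) and so reverses most of the earlier gain at this position. Methoxy in place of amino on the aromatic carbon gives a number 8 percentage points higher from compound 1 to compound 3 (within the scatter) and the two groups cannot be told apart here, so among the three groups shown only 3,4-dichlorophenyl stands out. Nothing available gives a reason for this difference.

The compounds shown leave open whether a phenyl ring carrying a single chlorine would read like the dichlorinated group or like the other two, and whether bromine or trifluoromethyl on that ring would do the same. They also leave open how these numbers would change at other concentrations, as each reflects one concentration only.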